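The compounds below may be only part of what the source reports. "The series", "measured", "known", "first", "only" and "open" are said of these compounds alone.

Measured so far in a functional assay on Bel-7402 cells (Homo sapiens) for inhibition, read by MTT assay, with a stated time of 24 h, tested at 10 ug/mL; a lower number here means less inhibition of growth, a higher number more inhibition of growth at the concentration tested
- compound 1 `O=C(CCCCC1CCSS1)Nc1ccc(OC(F)(F)F)cc1` gives 1.24%
- compound 2 `O=C(CCCCC1CCSS1)Nc1ccccn1` gives 5.77%
- compound 3 `O=C(CCCCC1CCSS1)Nc1ccc(Cl)cn1` gives 16.1%

Compound 3 stands highest of the three, beyond the scatter from both compound 2 and compound 1. Compound 4 `O=C(CCCCC1CCSS1)Nc1ccc(Br)cn1` is the next case, and the change is bromo in place of chloro on an aromatic carbon. Among the compounds with values here, one measured step bears on it, the modest a number 10.3 percentage points higher from compound 2 to compound 3 (beyond the scatter) for chloro in place of hydrogen on that same carbon. Within the data shown here, no measured step exchanges one halogen for another, so the evidence is thin. The estimate is a number 1.9 percentage points higher from compound 3 to compound 4 (within the scatter) in this assay and this expected small rise stays within the scatter. For compound 4 the estimated value is 18% (expected range 8% to 32%).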

Compound 4, percent growth inhibition at one concentration: 24.5%
Beside the measured number, compound 4's estimate is 6.5 percentage points below it; the range from low to high includes it.
By their numbers in this assay, from the lowest: compounds 1 and 2 (each within the scatter of the next); then compounds 3 and 4 (each within the scatter of the next).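

In this assay the exchange of one halogen for another at this carbon gives a number 8.4 percentage points higher from compound 3 to compound 4 (within the scatter), so bromo and chloro cannot be told apart on this read-out. Bromo in place of hydrogen on the same carbon, two atoms from the ring nitrogen, gives a number 18.7 percentage points higher from compound 2 to compound 4 (beyond the scatter), a second halogen step beyond the scatter alongside the chloro step. From the compounds shown here alone, whether an amine, a methoxy group or a nitrile on this carbon would match either halogen stays open. No measured evidence accounts for the halogen steps.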